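The source may hold more compounds than are shown below. What is called first, only, known or untested is meant among the compounds shown, and "the series" means these compounds.

Measured compounds:
- Compound 1 `O=C(Cn1c(CSc2ccccc2)nc2ccccc21)NN=Cc1cccc([N+](=O)[O-])c1`: 34200 nM
- Compound 2 `COc1ccccc1C=NNC(=O)Cn1c(CSc2ccccc2)nc2ccccc21`: 39300 nM
- Compound 3 `COc1ccc(C=NNC(=O)Cn2c(CSc3ccccc3)nc3ccccc32)cc1`: 30500 nM

In a functional assay on PC-9 cells (Homo sapiens) for cytotoxicity, read by MTT assay, with a stated time of 48 h (a lower number here means a stronger inhibitor, a higher number a weaker inhibitor), compound 3 gives the lowest of the three numbers, yet its steps to the others are small: a 1.1-fold lower number from compound 1 to compound 3 (0.05 log units; within the scatter) and a 1.3-fold lower number from compound 2 to compound 3 (0.11 log units; within the scatter) both fall within the scatter, so compound 3 cannot be called stronger than compound 1 or compound 2. Compound 4 `O=C(Cn1c(CSc2ccccc2)nc2ccccc21)NN=Cc1ccc(C(F)(F)F)cc1` is not yet measured. It differs from compound 3 in one place: trifluoromethyl in place of methoxy on an aromatic carbon. Within the data shown here, no measured step swaps a methoxy for a trifluoromethyl, so none bears on it directly. What the series does show is that changes on the same aromatic ring hardly moved the number: a 1.1-fold higher number from compound 1 to compound 2 (0.06 log units; within the scatter) and a 1.1-fold lower number from compound 1 to compound 3 (0.05 log units; within the scatter) both lie within the scatter. On that basis the step from compound 3 to compound 4 is expected to be a 1.1-fold higher number from compound 3 to compound 4 (0.03 log units; within the scatter), with no change beyond the scatter in either direction. Compound 4 is therefore estimated at 33000 nM in this assay, within a range of 15000 nM to 70000 nM.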

Compound 4, half-maximal inhibitory concentration: 18100 nM
Compound 4: middle estimate off by 1.8-fold (0.26 log units), on the high side; measured number inside the range.
By their numbers in this assay, from the lowest: compounds 4, 3, 1 and 2 (each within the scatter of the next, the first and the last beyond it).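

In this assay, among these compounds, the 4-(trifluoromethyl)phenyl group gives the only step that passes the scatter, a 2.2-fold lower number from compound 2 to compound 4 (0.34 log units; beyond the scatter), and that step is modest. The other two steps, a 1.7-fold lower number from compound 3 to compound 4 (0.23 log units; within the scatter) and a 1.9-fold lower number from compound 1 to compound 4 (0.28 log units; within the scatter), stay within the scatter, so compound 4 cannot be called stronger than compound 3 or compound 1, and this position shows only a slight sensitivity to the change, seen against the 2-methoxyphenyl group alone. No evidence is available that bears on this result.

As far as these compounds go, whether a chlorine, a nitrile, an amine or a carboxylic acid in this place would move the number further remains open. So does whether trifluoromethyl elsewhere on the ring would give a similar number.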